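The source may report more compounds than this note shows. Statements on the series, on what has been measured and on what is new or still open speak of the compounds shown alone.

Measured so far: compound 1 `CCN1CCN(c2cc(C)c3cc(NC(=O)c4ccccc4F)ccc3n2)CC1` gives 32600 nM; compound 2 `Cc1cc(NCCN(C)C)nc2ccc(NC(=O)c3ccc(Cl)c(Cl)c3)cc12` gives 2550 nM; compound 3 `CCN(CC)CCNc1cc(C)c2cc(NC(=O)c3ccc(Cl)c(Cl)c3)ccc2n1` gives 1420 nM.

In a functional assay on MCF7 cells (Homo sapiens) for antiproliferative activity, read by MTT assay, with a stated time of 72 h (on this read-out higher numbers stand for weaker inhibition and lower numbers for stronger inhibition), compound 1 stands highest of the three numbers, with compound 2 nearest and compound 3 furthest, both lower by more than the scatter. Compound 4 `CCc1ccc(C(=O)Nc2ccc3nc(N4CCN(CC)CC4)cc(C)c3c2)cc1` is reached from compound 1 by 4-ethylphenyl in place of 2-fluorophenyl on a carbonyl carbon. Among the measured compounds shown here, the only measured step, a 1.8-fold lower number from compound 2 to compound 3 (0.25 log units; within the scatter), alters the amine chain and not the group on the carbonyl carbon, so it does not bear on this change. Compounds 2 and 3 also differ from compound 1 in more than one place, so their lower numbers cannot be tied to the amide ring alone. For the measured compounds named here, with no step guiding the direction, the expected step of a 1.3-fold lower number from compound 1 to compound 4 (0.12 log units; within the scatter) is small and uncertain. Compound 4 is estimated at 25000 nM, between 8000 nM and 80000 nM.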

Compound 4, half-maximal inhibitory concentration: 3060 nM
For compound 4 the middle estimate is 8.2-fold (0.91 log units) above the measured one, and the stated range ends above it.
By their numbers in this assay, from the lowest: compounds 3, 2 and 4 (each within the scatter of the next, the first and the last beyond it); then compound 1.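

In this assay, the group on the carbonyl carbon strongly affects the result: replacing 2-fluorophenyl with 4-ethylphenyl gives a step beyond the scatter (an 11-fold lower number from compound 1 to compound 4 (1.03 log units; beyond the scatter)). Among the compounds shown here, the earlier measured step changed only the amine chain, so this is the first direct reading at this position. Nothing measured here explains the size of this step.

The compounds shown do not separate losing the fluorine from gaining the ethyl group. As far as these compounds go, it remains open what plain phenyl or 4-propylphenyl would give on the same carbonyl carbon.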